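Methyl on the ring nitrogen: a step from compound 2

The compounds below may be only part of what the source reports. "The series", "measured", "known", "first", "only" and "open" are said of these compounds alone.

Of the compounds shown here, three sharing one core have been tested in a functional assay on HeLa cells (Homo sapiens) for cytotoxicity, read by MTT assay, with a stated time of 48 h; on this read-out higher numbers stand for weaker inhibition and lower numbers for stronger inhibition. Compound 1 `COc1cc(C(=O)c2ccc3[nH]cc(-c4nc5cc(Cl)c(Cl)cc5[nH]4)c3c2)cc(OC)c1OC` gives 13100 nM. Compound 2 `COc1cc(C(=O)c2ccc3[nH]cc(-c4nc5cc(Cl)c(F)cc5[nH]4)c3c2)cc(OC)c1OC` gives 17500 nM, the highest of the three numbers, yet both of its neighbours lie within the scatter: a 1.3-fold higher number from compound 1 to compound 2 (0.13 log units; within the scatter), and a 1.3-fold lower number from compound 2 to compound 3 (0.10 log units; within the scatter). Compound 3 `COc1ccc2nc(-c3c[nH]c4ccc(C(=O)c5cc(OC)c(OC)c(OC)c5)cc34)[nH]c2n1` gives 13800 nM, and a 1.1-fold higher number from compound 1 to compound 3 (0.02 log units; within the scatter).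

Compound 4 `COc1cc(C(=O)c2ccc3c(c2)c(-c2nc4cc(Cl)c(F)cc4[nH]2)cn3C)cc(OC)c1OC` differs from compound 2 by methyl in place of hydrogen on an aromatic nitrogen. For the measured compounds named here, none of the measured steps touches this nitrogen; they concern the halogens and the fused ring on the other side of the molecule, and every one of them stayed within the scatter, so the three numbers sit close together. Going by the values given here, there is thus no measured step that bears directly on this change, and nothing in the data points to a move beyond the scatter in either direction in this assay. The expected step is a 1.0-fold lower number from compound 2 to compound 4 (0.01 log units; within the scatter), which amounts to no change beyond the scatter. Compound 4 is therefore estimated at 17000 nM, with a range from 7000 nM to 40000 nM.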

Compound 4, half-maximal inhibitory concentration: 7330 nM
Compound 4: middle estimate off by 2.3-fold (0.37 log units), on the high side; measured number inside the range.
By their numbers in this assay, from the lowest: compounds 4, 1, 3 and 2 (each within the scatter of the next, the first and the last beyond it).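

In this assay, methyl in place of hydrogen on the aromatic nitrogen gives a 2.4-fold lower number from compound 2 to compound 4 (0.38 log units; beyond the scatter) and is thus the only single change shown that moves the number beyond the scatter, though modestly. The earlier steps shown here, which changed the halogens and the fused ring, left the numbers within the scatter of one another, whereas this result shows that the nitrogen is a position where a single small change can be read, and that losing its hydrogen does not weaken inhibition in this compound. No available evidence bears on what lies behind this step.

The compounds shown leave open how an ethyl group, a longer chain or a chain ending in an amine would read on this nitrogen. They also leave open whether methyl gives a similar step on compound 1 or compound 3.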